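Removing the Methyl Between Ring Nitrogens on a Weak Inhibitor

The source may report more compounds than this note shows. Statements on the series, on what has been measured and on what is new or still open speak of the compounds shown alone.

Compound 3 `CCOC(=O)CSc1nncc2c(C)nc(C)n12` was tested in a functional assay for inhibition, with Homo sapiens as the target; a lower number here means a stronger inhibitor, a higher number a weaker inhibitor. In this assay compound 3 gives > 48000 nM, which is a limit of the assay and not a number. Compound 2 `CCCc1nc(C)c2cnnc(SCC(=O)OCC)n12` likewise gives > 48000 nM in this assay, again a limit rather than a number. Compound 1 `CCOC(=O)CSc1nncc2cnc(C)n12` gives 52000 nM in this assay. For the measured compounds named here, compound 3 thus stands at the limit of > 48000 nM in this assay, at which 2 of the 3 values shown sit, and the one number among the three, that of compound 1, lies close to it.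

Two measured steps lead into compound 3: a step that the limit leaves unreadable from compound 1 to compound 3, methyl in place of hydrogen on an aromatic carbon, and a step that the two limits leave unreadable from compound 2 to compound 3, hydrogen in place of ethyl on a saturated chain carbon bound to an aromatic carbon. Neither has a readable size.

Compound 4 `CCOC(=O)CSc1nncc2c(C)ncn12` differs from compound 3 by hydrogen in place of methyl on an aromatic carbon. Of the measured steps only a step that the limit leaves unreadable from compound 1 to compound 3 also concerns a methyl on an aromatic carbon, and it runs the other way with no readable size. No step beyond the scatter is therefore expected in this assay, and the expected step is a step that the limit leaves unreadable from compound 3 to compound 4. Compound 4 is estimated to give 55000 nM, within 25000 nM to 150000 nM, most likely reported again as a limit.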

Compound 4, half-maximal inhibitory concentration: > 48000 nM
Compound 4 gave a limit, no number (the forecaster's own chance of this, stated with the estimate: 60%); the middle value does not contradict the limit.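

Compound 4 gives only a limit in this assay, not a number, as do compound 2 and compound 3, so neither new step into compound 4 can be read: the limit of > 48000 nM in this assay, at which 3 of the 4 values shown sit.

The compounds shown leave open whether hydrogen in place of methyl between two ring nitrogen atoms shifts inhibition in either direction.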